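The source may report more compounds than this note shows. Statements on the series, on what has been measured and on what is new or still open speak of the compounds shown alone.

Three compounds that share one core and differ only in the group on an aromatic nitrogen have been measured in a functional assay on HL-60 cells (Homo sapiens) for inhibition; on this read-out lower numbers stand for stronger inhibition and higher numbers for weaker inhibition. Compound 1 (`CCn1nc(-c2ccc(OC)cc2)c(-c2ccc(OC)cc2)cc1=O`), with ethyl, gives 610 nM. Compound 3 (`COc1ccc(-c2cc(=O)n(C)nc2-c2ccc(OC)cc2)cc1`), with methyl, gives 1130 nM, and this pair cannot be separated: a 1.9-fold higher number from compound 1 to compound 3 (0.27 log units; within the scatter). Compound 2 (`COc1ccc(-c2cc(=O)n(C3CC3)nc2-c2ccc(OC)cc2)cc1`), with cyclopropyl, gives 7980 nM, the weakest of the three.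

Compound 4 (`COc1ccc(-c2cc(=O)n(CC3CC3)nc2-c2ccc(OC)cc2)cc1`) turns the methyl of compound 3 into cyclopropylmethyl: cyclopropyl in place of hydrogen on a saturated chain carbon bound to an aromatic nitrogen. Among the measured compounds shown here, the closest precedent is the same kind of change at the same carbon, a 1.9-fold higher number from compound 1 to compound 3 (0.27 log units; within the scatter). The larger steps, a 13-fold higher number from compound 1 to compound 2 (1.12 log units; beyond the scatter) and a 7.1-fold lower number from compound 2 to compound 3 (0.85 log units; beyond the scatter), involve a cyclopropyl on the nitrogen itself, so they bear only loosely, though they warn of a possible rise. In this assay, no change beyond the scatter is the likeliest outcome, and the estimated step is a 1.2-fold higher number from compound 3 to compound 4 (0.06 log units; within the scatter). For compound 4 the expected value is 1300 nM, with an estimated range from 350 nM to 6000 nM.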

Compound 4, half-maximal inhibitory concentration: 1800 nM
Compound 4: middle estimate off by 1.4-fold (0.14 log units), on the low side; the range from low to high includes it.
By their numbers in this assay, from the lowest: compounds 1, 3 and 4 (each within the scatter of the next, the first and the last beyond it); then compound 2.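

In this assay, adding a cyclopropyl on the saturated chain carbon bound to an aromatic nitrogen leaves the result within the scatter (a 1.6-fold higher number from compound 3 to compound 4 (0.20 log units; within the scatter)), so methyl and cyclopropylmethyl cannot be told apart. The placement of the ring matters: with one carbon between it and the nitrogen, the number is well clear of that for cyclopropyl directly on the nitrogen (a 4.4-fold lower number from compound 2 to compound 4 (0.65 log units; beyond the scatter)), yet ethyl and cyclopropylmethyl also separate beyond the scatter (a 3.0-fold higher number from compound 1 to compound 4 (0.47 log units; beyond the scatter)). Nothing available explains these differences.

From the compounds shown here alone, whether a longer unbranched chain such as propyl or butyl would stay close to ethyl remains open. So does the effect of a chain ending in an amine or a carboxylic acid at this nitrogen.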